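Swapping 4-chlorophenyl for 2-fluorophenyl on a shared core

The source may report more compounds than this note shows. Statements on the series, on what has been measured and on what is new or still open speak of the compounds shown alone.

Values in a functional assay on HeLa cells (Homo sapiens) for antiproliferative activity, read by MTT assay, with a stated time of 72 h; a higher number here means a weaker inhibitor, a lower number a stronger inhibitor:
Compound 1 `Nc1nc(N)c2cc(CSC(=S)N3CCN(c4ccccc4)CC3)ccc2n1`: 2840 nM
Compound 2 `Nc1nc(N)c2cc(CSC(=S)N3CCN(c4ccc(O)cc4)CC3)ccc2n1`: 5180 nM
Compound 3 `Nc1nc(N)c2cc(CSC(=S)N3CCN(c4ccc(Cl)cc4)CC3)ccc2n1`: 6990 nM

Compound 3 shares the high, weaker end of this small set with compound 2, and the two cannot be told apart, as a 1.3-fold higher number from compound 2 to compound 3 (0.13 log units; within the scatter) shows. It stands clearly apart only from compound 1, with a 2.5-fold higher number from compound 1 to compound 3 (0.39 log units; beyond the scatter). The hydroxy change gave a 1.8-fold higher number from compound 1 to compound 2 (0.26 log units; within the scatter).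

Compound 4 `Nc1nc(N)c2cc(CSC(=S)N3CCN(c4ccccc4F)CC3)ccc2n1` has 2-fluorophenyl in place of 4-chlorophenyl on an amine nitrogen in a ring. Among the compounds with values here, no measured compound carries fluorine, so the data show nothing direct about this group. The chloro group goes, though, and its addition gave a 2.5-fold higher number from compound 1 to compound 3 (0.39 log units; beyond the scatter), a modest step, so part of that rise may be undone. A small fall in this assay is therefore expected, probably within the scatter. The estimate is a 1.7-fold lower number from compound 3 to compound 4 (0.22 log units; within the scatter). For compound 4 the estimated value is 4200 nM, with an expected range of 1900 nM to 8500 nM.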

Compound 4, half-maximal inhibitory concentration: 6660 nM
Compound 4: the middle estimate sits 1.6-fold (0.20 log units) below what was measured; low and high end bracket the measured number.
By their numbers in this assay, from the lowest: compounds 1, 2, 4 and 3 (each within the scatter of the next, the first and the last beyond it).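

In this assay, exchanging 4-chlorophenyl for 2-fluorophenyl leaves the number effectively unchanged, with a 1.0-fold lower number from compound 3 to compound 4 (0.02 log units; within the scatter). Compound 4 also cannot be told apart from the hydroxy analogue, with a 1.3-fold higher number from compound 2 to compound 4 (0.11 log units; within the scatter), whereas adding fluoro to the plain phenyl gives a 2.3-fold higher number from compound 1 to compound 4 (0.37 log units; beyond the scatter), a modest rise. Compound 3 and compound 4 therefore both stand apart from compound 1, while compound 2 goes against any simple rule that every substituent on this phenyl ring raises the number, since its step from compound 1 lies within the scatter.

No measurement here explains these small differences. The compounds shown also leave the halogen and its place on the ring tangled together, so 4-fluorophenyl or 2-chlorophenyl would be needed to separate those two changes.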